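A few compounds are considered here, and "the series" means these few. Any claim that something is new, unique, unknown or untested is made for them only; others in the source may bear on it.

Measured in a functional assay on DU-145 cells (Homo sapiens) for cytotoxicity, read by ELISA, with a stated time of 4 days (a higher number here means a weaker inhibitor, a lower number a stronger inhibitor), are:
Compound 1 `Cc1ccsc1-c1cc(-c2ccoc2)cc(-c2ccc(Cl)cc2)n1` gives 20100 nM
Compound 2 `Clc1ccc(-c2cc(-c3ccco3)cc(-c3ccc(Cl)s3)n2)cc1` gives 14800 nM
Compound 3 `Clc1ccc(-c2cc(-c3ccoc3)cc(-c3ccco3)n2)s1` gives 17200 nM

Compound 3 at 17200 nM stands within the scatter of both other compounds, so no order among the three can be read. Compound 4 `Cc1cccc(-c2cc(-c3ccoc3)cc(-c3ccc(Cl)s3)n2)c1` carries 3-methylphenyl in place of furan-2-yl on an aromatic carbon, next to the ring nitrogen (3-methylphenyl in place of furan-2-yl on an aromatic carbon). Among the compounds with values here, no measured pair differing in one place is available to size this change. Still, compound 2 at 14800 nM and compound 1 at 20100 nM show no spread beyond the scatter despite their different groups, so no step beyond the scatter is expected here. The expected change is a 1.1-fold lower number from compound 3 to compound 4 (0.06 log units; within the scatter) and it stays within that scatter. In this assay compound 4 is estimated at 15000 nM within an expected range (7000 nM to 32000 nM).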

Compound 4, half-maximal inhibitory concentration: 20300 nM
Beside the measured number, compound 4's estimate is 1.4-fold (0.13 log units) below it, and the stated range covers the measured number.
By their numbers in this assay, from the lowest: compounds 2, 3, 1 and 4 (each within the scatter of the next).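

In this assay, within the data shown here, 3-methylphenyl in place of furan-2-yl on an aromatic carbon, next to the ring nitrogen, gives a 1.2-fold higher number from compound 3 to compound 4 (0.07 log units; within the scatter) and is the first step at this position that can be sized. It shows that a six-membered aromatic ring of carbon only can stand here in place of a five-membered aromatic ring with no readable change in the number. Nothing at hand offers an explanation for this result.

The compounds shown carry only aromatic rings at this position, so the effect of an amine or a carboxylic acid there remains open.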